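Clearance of compound 3 after a swap from cyano

This account rests on a few compounds, and the source may have more. Where it says the series, first, only, none or still open, it means among the compounds named here.

Compound 1 `CCn1cnc2c(-c3ccnc(Oc4cccc(S(=O)(=O)CC)c4)c3)cnnc21`: < 8 mL.min-1.g-1 (a limit of the assay)
Compound 2 `CCn1cnc2c(-c3ccc(F)c(-c4ccc(C#N)cc4OC)c3)cnnc21`: 32 mL.min-1.g-1

For the measured compounds named here, in an ADME assay on microsomes from liver (Homo sapiens) for metabolic stability (a lower number here means slower removal, a higher number faster removal of the compound), compound 2 gives 32 mL.min-1.g-1 as the only true number so far. Compound 1 stands at < 8 mL.min-1.g-1, which is a limit of the assay and not a number.

Compound 3 `CCn1cnc2c(-c3ccc(F)c(-c4ccc(S(=O)(=O)C5CC5)cc4OC)c3)cnnc21` follows from compound 2 by one change, with cyclopropylsulfonyl in place of cyano on an aromatic carbon, meta to a methoxy group and para to a large group: cyclopropylsulfonyl in place of cyano on an aromatic carbon. Going by the values given here, no measured pair shows this change directly, so what follows is an expectation and not a finding.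

A modest fall in this assay is expected, resting only on compound 1 with its limit of < 8 mL.min-1.g-1, since its structure also holds a sulfonyl group. The estimated size is a 1.6-fold lower number from compound 2 to compound 3 (0.20 log units; within the scatter) and is expected to stay near the usual scatter, so a result level with compound 2 would not surprise.

For compound 3 the expected value is 20 mL.min-1.g-1, with an estimated range from 10 mL.min-1.g-1 to 40 mL.min-1.g-1.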

Compound 3, intrinsic clearance in microsomes: < 12 mL.min-1.g-1
Compound 3 ended at the assay's limit; the forecaster's own chance of this, stated with the estimate: 10%; at least 1.6-fold (0.22 log units) between middle value and limit.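

At the aromatic carbon meta to a methoxy group and para to a large group, cyclopropylsulfonyl in place of cyano gives, in this assay, an at least 2.6-fold lower number from compound 2 to compound 3 (0.42 log units; beyond the scatter). This single change now carries a reading of its own and lies beyond the scatter, whereas compound 1 shares a sulfonyl group with compound 3 but differs from compound 2 in more than one place and so could not show what a sulfonyl group does at this position. The step gives only a minimum size, because compound 3 stands at a limit of the assay and not at a number: the limit of < 12 mL.min-1.g-1 in this assay, at which 1 of the 3 values shown sits.

The compounds shown leave open how much lower the true clearance of compound 3 lies, and whether the sulfonyl group alone accounts for the step or the three-membered ring also contributes. An ethylsulfonyl or methylsulfonyl group on the same carbon would separate those two parts, while a primary sulfonamide there would test whether the step holds with an amine nitrogen on the sulfur.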